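Butoxy to allyloxy: expected step in the series

The compounds below may be only part of what the source reports. "The series", "measured", "known", "first", "only" and "open" are said of these compounds alone.

In a functional assay on the whole organism (strain Sprague-Dawley) for inhibition, with Rattus norvegicus as the target, with a stated time of 10 min (a higher number here means that more compound is needed for the effect, a lower number that less compound is needed), compound 1 `O=C(O)c1cnc(-c2ccccc2)[nH]c1=O` gives 50 mg/kg, compound 2 `O=C(O)c1cnc(-c2ccccc2F)[nH]c1=O` gives 5 mg/kg and compound 3 `CCCCOc1ccccc1-c1ncc(C(=O)O)c(=O)[nH]1` gives 0.5 mg/kg, the lowest of the three numbers. Compound 4 `C=CCOc1ccccc1-c1ncc(C(=O)O)c(=O)[nH]1` turns butoxy into allyloxy, with vinyl in place of propyl on a saturated chain carbon bound to an oxygen on an aromatic ring. Within the data shown here, no measured step alters this chain. The closest evidence is a 100-fold lower number from compound 1 to compound 3 (2.00 log units; beyond the scatter), a large step, and a 10-fold lower number from compound 2 to compound 3 (1.00 log units; beyond the scatter), a modest one, and both install the whole butoxy group. Here only propyl gives way to vinyl, so little change is anticipated in this assay. The expected step is a 1.6-fold higher number from compound 3 to compound 4 (0.20 log units; within the scatter), slightly upward and within the scatter. Compound 4 is estimated at 0.8 mg/kg, with an expected range of 0.25 mg/kg to 2.5 mg/kg.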

Compound 4, dose for 50% inhibition: 0.5 mg/kg
For compound 4 the middle estimate is 1.6-fold (0.20 log units) above the measured one, within the range that was stated.
By their numbers in this assay, from the lowest: compounds 3 and 4 (each within the scatter of the next); then compound 2; then compound 1.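

In this assay allyloxy can take over from butoxy, with no change at the digits printed from compound 3 to compound 4 (within the scatter) as the result, so the full butyl chain is not required at this level. Allyloxy also carries the gain seen earlier with butoxy, showing a 10-fold lower number from compound 2 to compound 4 (1.00 log units; beyond the scatter) when it replaces fluoro and a 100-fold lower number from compound 1 to compound 4 (2.00 log units; beyond the scatter) when it replaces hydrogen. Nothing available accounts for the two chains reading alike.

Still open, on these data alone, is whether a shorter methoxy group or a longer hexyloxy chain would hold this level. The effect of an amine at the end of the chain is also unknown.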